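This account rests on a few compounds, and the source may have more. Where it says the series, first, only, none or still open, it means among the compounds named here.

Three close relatives of one shared core have been measured in a functional assay for agonist activity at Alpha-1A adrenergic receptor (Homo sapiens); a lower number here means that less compound is needed, a higher number that more compound is needed for the effect. Compound 1 `CSc1ccc(C)cc1NCC1=NCCN1` gives 0.11 nM and stands lowest of the three measured numbers. Within the data shown here, compound 2 `Cc1ccc(S(C)(=O)=O)c(NCC2=NCCN2)c1` gives 1.95 nM, and the step of an 18-fold higher number from compound 1 to compound 2 (1.25 log units; beyond the scatter) is the only change of a single group among the measured pairs. Compound 3 `CS(=O)(=O)c1cc(Cl)ccc1NCC1=NCCN1` gives 513 nM, the highest of the three, but it differs from compound 1 and from compound 2 in more than one place, so those pairs show only the gap between their two values.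

The unmeasured compound 4 `CSc1ccc(C(F)(F)F)cc1NCC1=NCCN1` alters compound 1 as follows: trifluoromethyl in place of methyl on an aromatic carbon. Among the measured compounds shown here, no measured step touches this group: the change from compound 1 to compound 2 replaced the methylsulfanyl group, which compound 4 keeps unchanged. The measured steps therefore give no direct guide, and the expectation rests on compound 1 alone. For compound 4 a small rise is expected, with a 3.6-fold higher number from compound 1 to compound 4 (0.56 log units; beyond the scatter) as the estimated step. The estimate for compound 4 is 0.4 nM, within a range from 0.08 nM to 2 nM.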

Compound 4, half-maximal effective concentration: 10.5 nM
The estimate for compound 4 lay 26-fold (1.42 log units) below the measured number; measured number outside the range, above it.
By their numbers in this assay, from the lowest: compound 1; then compound 2; then compound 4; then compound 3.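

In this assay, the aromatic carbon para to the methylsulfanyl group proves to be a sensitive place: trifluoromethyl in place of methyl gives a 95-fold higher number from compound 1 to compound 4 (1.98 log units; beyond the scatter). Among these compounds, the only earlier single-group step, an 18-fold higher number from compound 1 to compound 2 (1.25 log units; beyond the scatter), changed the methylsulfanyl group itself, so this is the first sign that the group on the opposite side of that ring also has a large influence on the number. Nothing available explains why the number rises with this change.

This single swap, from a group of 1 heavy atom to one of 4, cannot show which feature of trifluoromethyl matters. Going by these compounds, how an ethyl group, a methoxy group or a single fluorine would behave at this place on the core of compound 1 remains open.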